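Ester variation on a thienyl dihydropyrimidinone series

This account rests on a few compounds, and the source may have more. Where it says the series, first, only, none or still open, it means among the compounds named here.

Measured compounds:
compound 1 `CC1=C(C(=O)OCc2ccccc2)C(c2cccs2)NC(=O)N1` — 45%
compound 2 `CCOC(=O)C1=C(C)N(C)C(=O)NC1c1cccs1` — 1%
compound 3 `CC1=C(C(=O)OC(C)(C)C)C(c2cccs2)NC(=O)N1C` — 18%

In an assay on membranes from CHO cells for displacement of a labelled ligand from adenosine receptor A1 (Homo sapiens), read by scintillation counting, with a stated time of 60 min, tested at 1 uM (on this read-out higher numbers stand for more inhibition at the one concentration tested (going by the name of the read-out) and lower numbers for less inhibition), compound 3 gives 18%, the second highest of the three numbers; compound 2 lies nearer, compound 1 further. Going by the values given here, the one step that bears on the next change is a number 17 percentage points higher from compound 2 to compound 3 (beyond the scatter), a modest rise. Compound 4 `CC1=C(C(=O)OCc2ccccc2)C(c2cccs2)NC(=O)N1C` differs from compound 3 by benzyl in place of tert-butyl on an oxygen next to a carbonyl group. Compound 1 carries the same benzyl group on the same oxygen and gives 45%, though it differs from compound 4 elsewhere, so no step for that pair is shown. Given compound 3 at 18%, a further rise is expected, a number 14 percentage points higher from compound 3 to compound 4 (beyond the scatter), landing short of compound 1. Compound 4 is estimated at 32%, within 12% to 52%.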

Compound 4, a percentage reported as inhibition, at one concentration (the size of the read-out at that concentration, not a potency): 50%
The estimate for compound 4 lay 18 percentage points below the measured number; measured number inside the range.
By their numbers in this assay, from the lowest: compound 2; then compound 3; then compounds 1 and 4 (each within the scatter of the next).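

In this assay benzyl in place of tert-butyl on this oxygen gives a number 32 percentage points higher from compound 3 to compound 4 (beyond the scatter) as a large step, and phenyl in place of methyl on the saturated chain carbon bound to this oxygen gives a number 49 percentage points higher from compound 2 to compound 4 (beyond the scatter) as a large step too. With benzyl on this oxygen, methyl in place of hydrogen on the amide-type nitrogen in the ring gives a number 5 percentage points higher from compound 1 to compound 4 (within the scatter) and so separates compound 1 and compound 4 by no more than the scatter. No supporting data explain the rise. Open, as far as these compounds go, is how a longer chain, a cyclohexylmethyl group or a benzyl carrying an amine would read on this oxygen.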